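The source may report more compounds than this note shows. Statements on the series, on what has been measured and on what is new or still open speak of the compounds shown alone.

In a functional assay on MDA-MB-231 cells (Homo sapiens) for cytotoxicity, read by MTT assay, with a stated time of 68 h (a lower number here means a stronger inhibitor, a higher number a weaker inhibitor), compound 1 (`O=C(/C=C/c1cccc(OCc2ccccc2)c1)c1ccc(Cl)cc1Cl`) gives 6800 nM and sits level with compound 2 (`O=C(/C=C/c1cccc(OCc2ccccc2)c1)c1ccc(Br)cc1`) at 6400 nM as the step of a 1.1-fold lower number from compound 1 to compound 2 (0.03 log units; within the scatter) shows. Compound 3 (`O=C(/C=C/c1cccc(OCc2ccccc2)c1)c1ccccc1Br`) gives 1800 nM and holds the lowest number of the three. Compound 4 (`O=C(/C=C/c1cccc(OCc2ccccc2)c1)c1ccccc1`) has not yet been measured. It differs from compound 1 in one place: phenyl in place of 2,4-dichlorophenyl on a carbonyl carbon with phenyl in place of 2,4-dichlorophenyl on a carbonyl carbon.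

Among the measured compounds shown here, no measured compound carries this plain phenyl, so the evidence is indirect. The step of a 1.1-fold lower number from compound 1 to compound 2 (0.03 log units; within the scatter) shows that one exchange on this ring left the number unmoved beyond the scatter. Only compound 3 stands apart, through the modest steps of a 3.8-fold lower number from compound 1 to compound 3 (0.58 log units; beyond the scatter) and a 3.6-fold lower number from compound 2 to compound 3 (0.55 log units; beyond the scatter) and it alone carries 2-bromophenyl, which compound 4 lacks. Compound 4 therefore seems closer in kind to compound 2, although the data cannot show what removing every ring substituent does. What is expected in this assay is a 1.5-fold lower number from compound 1 to compound 4 (0.18 log units; within the scatter) and so no clear move beyond the scatter, with a slight lean toward a lower number. Compound 4 is estimated at 4500 nM with 1800 nM to 10000 nM as the expected range.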

Compound 4, half-maximal inhibitory concentration: 20000 nM
Compound 4: middle estimate off by 4.4-fold (0.65 log units), on the low side; the measured number lies above the stated range.
By their numbers in this assay, from the lowest: compound 3; then compounds 2 and 1 (each within the scatter of the next); then compound 4.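

In this assay the plain phenyl on the carbonyl carbon stands apart from all three halogen-bearing rings, which the level pair of compounds 1 and 2 could not reveal: their agreement did not mean that this ring tolerates any change, as the loss of both chlorines gives (a 2.9-fold higher number from compound 1 to compound 4 (0.47 log units; beyond the scatter)) and the loss of the single bromo from 4-bromophenyl gives (a 3.1-fold higher number from compound 2 to compound 4 (0.49 log units; beyond the scatter)). The loss of bromo from 2-bromophenyl gives the only large step in the series (an 11-fold higher number from compound 3 to compound 4 (1.05 log units; beyond the scatter)), so among these four compounds every halogen-bearing ring has a lower number than phenyl, none goes against this, and the 2-bromophenyl ring has the lowest number of all. No measurement offered here explains why a substituent on this ring matters or why the 2-bromophenyl ring stands out.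

The compounds shown leave open whether these lower numbers belong to halogens in particular or would also appear with a methoxy group or an amine on this ring. They also leave open whether 2-chlorophenyl or 2-fluorophenyl would match the 2-bromophenyl ring of compound 3, or whether that number is particular to bromo.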